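A few compounds are considered here, and "the series" means these few. Any claim that something is new, unique, unknown or untested is made for them only; others in the source may bear on it.

Measured compounds:
- compound 1 `O/N=C(\CCN1CCN(c2ccccn2)CC1)c1ccccc1Cl`: 24 nM
- compound 2 `Cc1ccccc1/C(CCN1CCN(c2ccccn2)CC1)=N/O`: 4.2 nM
- compound 3 `O/N=C(\CCN1CCN(c2ccccn2)CC1)c1ccc(F)cc1F`: 8.9 nM

In a functional assay on HEK293 cells with D(4) dopamine receptor (Homo sapiens) as the target, read by FLIPR (on this read-out higher numbers stand for an effect only at larger amounts of compound and lower numbers for an effect already at smaller amounts), compound 1 stands with the highest number of the three, and its nearest neighbour is compound 3, while compound 2 lies furthest from it. The two measured steps that leave compound 1 both move in the same direction: a 5.7-fold lower number from compound 1 to compound 2 (0.76 log units; beyond the scatter) and a 2.7-fold lower number from compound 1 to compound 3 (0.43 log units; beyond the scatter). Between the two new partners, a 2.1-fold higher number from compound 2 to compound 3 (0.33 log units; beyond the scatter).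

Compound 4 `Cc1ccc(O)c(/C(CCN2CCN(c3ccccn3)CC2)=N/O)c1` has not yet been measured in this assay. It differs from compound 1 at the same carbon that was changed in the measured steps, in this way:

2-hydroxy-5-methylphenyl in place of 2-chlorophenyl on a carbon with a double bond to nitrogen

Both measured steps from compound 1 bear on this change, since each swaps out the 2-chlorophenyl on the carbon with a double bond to nitrogen and each gives a modest lower number. For the measured compounds named here, the 2-hydroxy-5-methylphenyl that enters, however, brings a hydrogen-bond donor and acceptor that none of the measured partners carries, so the measured steps are only a partial guide. The account therefore expects a step for compound 4 of about a 1.6-fold lower number from compound 1 to compound 4 (0.20 log units; within the scatter), a modest move toward a lower number or none beyond the scatter. For compound 4 the estimated value in this assay is 15 nM, with a range from 4 nM to 60 nM.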

Compound 4, half-maximal effective concentration: 19.2 nM
Compound 4: middle estimate off by 1.3-fold (0.11 log units), on the low side; measured number inside the range.
By their numbers in this assay, from the lowest: compound 2; then compound 3; then compounds 4 and 1 (each within the scatter of the next).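

In this assay, every earlier replacement of the 2-chlorophenyl on the carbon with a double bond to nitrogen had given a number lower beyond the scatter, but 2-hydroxy-5-methylphenyl does not, with a 1.3-fold lower number from compound 1 to compound 4 (0.10 log units; within the scatter). The position therefore accepts a ring carrying a hydrogen-bond donor and acceptor without a change beyond the scatter from compound 1, yet the new group stands apart from the other two replacements, with a 2.2-fold higher number from compound 3 to compound 4 (0.33 log units; beyond the scatter) and a 4.6-fold higher number from compound 2 to compound 4 (0.66 log units; beyond the scatter), so a lower number does not follow from every replacement of 2-chlorophenyl at this place. Nothing available gives a measured reason for these differences.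

The compounds shown leave open how the hydroxy and the methyl of the entering group each contribute, which a plain phenyl, a hydroxyphenyl without the methyl, or a methoxy in place of the hydroxy could separate. They also leave open whether the same order among these aromatic groups would hold with a longer chain in place of the saturated chain that joins this carbon to the rest of the shared core.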